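Moving a methyl group on the outer ring of compound 1

The source may report more compounds than this note shows. Statements on the series, on what has been measured and on what is new or still open speak of the compounds shown alone.

Measured so far in a functional assay on HCC827 cells (Homo sapiens) for inhibition, read by MTT assay, with a stated time of 48 h, tested at 10 uM; on this read-out higher numbers stand for more inhibition at the one concentration tested (going by the name of the read-out) and lower numbers for less inhibition:
compound 1 `COc1cc(NC(=O)Nc2cc(Nc3ccc(C)c(F)c3)ncn2)cc(OC)c1` gives 72%;
compound 2 `COc1ccc(Nc2cc(NC(=O)Nc3c(Cl)cccc3Cl)ncn2)cc1C` gives 63.1%;
compound 3 `COc1cc(Nc2cc(NC(=O)Nc3c(Cl)cccc3Cl)ncn2)cc(C(F)(F)F)c1` gives 57.7%.

Compound 1 has the highest of the three numbers. Compound 2 lies within the scatter of it, so the two cannot be ranked; compound 3 lies beyond the scatter, so compound 1 does give more inhibition than compound 3. Compound 4 `COc1cc(NC(=O)Nc2cc(Nc3cc(C)cc(F)c3)ncn2)cc(OC)c1` has the same atoms as compound 1 joined differently: 3-fluoro-5-methylphenyl in place of 3-fluoro-4-methylphenyl on a nitrogen on an aromatic ring. Within the data shown here, no measured pair shows what such a move does here. The expected step of a number 7 percentage points lower from compound 1 to compound 4 (within the scatter) is small, not beyond the scatter. Compound 4 is estimated at 65%, between 45% and 80%.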

Compound 4, a percentage reported as inhibition, at one concentration (the size of the read-out at that concentration, not a potency): 62.1%
Beside the measured number, compound 4's estimate is 2.9 percentage points above it; low and high end bracket the measured number.
By their numbers in this assay, from the lowest: compounds 3, 4, 2 and 1 (each within the scatter of the next, the first and the last beyond it).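

In this assay, among these compounds, 3-fluoro-5-methylphenyl in place of 3-fluoro-4-methylphenyl on the nitrogen gives the only measured pair that differs in one place (a number 9.9 percentage points lower from compound 1 to compound 4 (within the scatter)). Moving the methyl group on this outer ring, with the same atoms kept, therefore gives no difference that can be told apart from the usual scatter at the one concentration tested. Nothing available here offers an explanation for this result. Still open, on these data alone, is whether an ethyl group or an amine in place of the methyl would give a step beyond the scatter. A full concentration series could also show differences that a single concentration cannot.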